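The compounds below may be only part of what the source reports. "The series", "measured", "known", "first", "only" and "open" are said of these compounds alone.

Measured in a physicochemical assay for pharmacokinetics; a lower number here means that the compound disappears faster, a higher number that the compound lasts longer:
compound 1 `O=C(NCc1ccccc1Br)N1C(=O)c2ccccc2S1(=O)=O`: 0.253 h
compound 2 `COc1cccc(CNC(=O)N2C(=O)c3ccccc3S2(=O)=O)c1`: 0.523 h
compound 3 `O=C(NCc1ccccc1F)N1C(=O)c2ccccc2S1(=O)=O`: 0.598 h

Compound 3 shares the upper end of this small range with compound 2, and compound 1 lies lower. The next structure is compound 4 `O=C(NCc1cccc(Br)c1)N1C(=O)c2ccccc2S1(=O)=O`, with 3-bromophenyl in place of 2-fluorophenyl on a saturated chain carbon bound to an amide-type nitrogen.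

Within the data shown here, two measured steps bear on this change. The first, a 2.4-fold higher number from compound 1 to compound 3 (0.37 log units; beyond the scatter), is fluoro in place of bromo on an aromatic carbon, and read backwards it points to a lower number. The second, a 1.1-fold higher number from compound 2 to compound 3 (0.06 log units; within the scatter), shows no separation between 3-methoxyphenyl and 2-fluorophenyl, which tempers that expectation.

The expected change is toward a lower number, a 1.7-fold lower number from compound 3 to compound 4 (0.22 log units; within the scatter). The estimate for compound 4 is 0.36 h, with an expected range of 0.2 h to 0.62 h.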

Compound 4, half-life: 0.492 h
Compound 4: the middle estimate sits 1.4-fold (0.14 log units) below what was measured; low and high end bracket the measured number.
By their numbers in this assay, from the lowest: compounds 1, 4, 2 and 3 (each within the scatter of the next, the first and the last beyond it).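

In this assay, 3-bromophenyl in place of 2-fluorophenyl on a saturated chain carbon bound to an amide-type nitrogen gives no separation (a 1.2-fold lower number from compound 3 to compound 4 (0.08 log units; within the scatter)), and bromo in place of methoxy gives none either (a 1.1-fold lower number from compound 2 to compound 4 (0.03 log units; within the scatter)). 3-bromophenyl in place of 2-bromophenyl also stays unresolved (a 1.9-fold higher number from compound 1 to compound 4 (0.29 log units; within the scatter)), so compound 4 separates from none of the other three, and the bromo-bearing ring of compound 4 cannot be assigned to either end of the range. Nothing available explains these numbers.

Still open, from the compounds shown here alone, is whether an amine or a carboxylic acid on the phenyl ring would leave this narrow range. Going by these compounds, a longer chain at the saturated chain carbon is equally open.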